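Adding a chloro group to compound 2

The source may report more compounds than this note shows. Statements on the series, on what has been measured and on what is new or still open speak of the compounds shown alone.

Measured in an ADME assay on Caco-2 cells (Homo sapiens) for permeability, in the apical to basolateral direction, at pH 7.4; a higher number here means that the compound crosses the layer faster, a lower number that the compound crosses the layer more slowly:
- compound 1 `Cc1csc(C(=O)N[C@H]2CN(S(=O)(=O)c3ccccc3)C[C@@H]2C(=O)N[C@H]2CCCNC2)n1`: 0.18 10^-6 cm/s
- compound 2 `O=C(N[C@H]1CN(S(=O)(=O)c2ccccc2)C[C@@H]1C(=O)N[C@H]1CCCNC1)c1cc(-c2ccccc2)on1`: 0.12 10^-6 cm/s

Only these two compounds have been measured, and compound 2 stands within the scatter of compound 1, the step being a 1.5-fold lower number from compound 1 to compound 2 (0.18 log units; within the scatter). Compound 3 `O=C(N[C@H]1CN(S(=O)(=O)c2ccccc2)C[C@@H]1C(=O)N[C@H]1CCCNC1)c1cc(-c2ccc(Cl)cc2)on1` differs from compound 2 in one place: chloro in place of hydrogen on an aromatic carbon. This is chloro in place of hydrogen on an aromatic carbon, which turns phenyl into 4-chlorophenyl and 5-phenyl-1,2-oxazol-3-yl into 5-(4-chlorophenyl)-1,2-oxazol-3-yl.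

Among the compounds with values here, no measured step adds a chloro group, so the data give no direct guide. Within the data shown here, the one step available, a 1.5-fold lower number from compound 1 to compound 2 (0.18 log units; within the scatter), replaced 4-methyl-1,3-thiazol-2-yl with 5-phenyl-1,2-oxazol-3-yl on a carbonyl carbon. It bears on the new change only indirectly, as an exchange at the same carbonyl that stayed within the scatter. On that single precedent, no step beyond the scatter is expected in this assay, and no firm direction can be given. The expected step is a 1.1-fold lower number from compound 2 to compound 3 (0.04 log units; within the scatter). Compound 3 is estimated at 0.11 10^-6 cm/s, with an expected range from 0.05 10^-6 cm/s to 0.25 10^-6 cm/s.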

Compound 3, apparent permeability: < 0.01 10^-6 cm/s
Compound 3: only a limit was reported; the forecaster's own chance of this, stated with the estimate: 10%; at least 11-fold (1.04 log units) between middle value and limit.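

In this assay, compound 3 gives a limit of the assay and not a number: the limit of < 0.01 10^-6 cm/s in this assay, at which 1 of the 3 values shown sits.

On the six-membered aromatic ring, para to a large group, chloro in place of hydrogen gives an at least 12-fold lower number from compound 2 to compound 3 (1.07 log units; beyond the scatter), so a single added atom here moves the read-out much further than the whole exchange of groups on the carbonyl carbon, a 1.5-fold lower number from compound 1 to compound 2 (0.18 log units; within the scatter), which stayed within the scatter. With 5-(4-chlorophenyl)-1,2-oxazol-3-yl in place of 4-methyl-1,3-thiazol-2-yl, the step is an at least 18-fold lower number from compound 1 to compound 3 (1.25 log units; beyond the scatter), so a change on that carbonyl carbon does go beyond the scatter once the chloro is present, which the earlier pair could not show.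

The size of the drop stays open, since a limit gives no end point for either step, and the compounds shown cannot tell whether chloro is special or whether another group in the same place, such as fluoro, methyl or methoxy, would do the same. They also leave open whether an amine or a carboxylic acid on this phenyl ring would move the number the other way.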